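Changing the Acyl Group on a Shared Core

A few compounds are considered here, and "the series" means these few. Any claim that something is new, unique, unknown or untested is made for them only; others in the source may bear on it.

Three compounds sharing one core differ only in the group on a carbonyl carbon. In a functional assay on A549 cells (Homo sapiens) for cytotoxicity, read by MTT assay, with a stated time of 48 h (on this read-out higher numbers stand for weaker inhibition and lower numbers for stronger inhibition), compound 1 (`C=C1C(=O)O[C@H]2CC3=C[C@H](C/C(C)=C/[C@@H](OC(=O)c4ccc(C(C)=O)cc4)[C@H]12)OC3=O`) gives 2300 nM, compound 2 (`C=C1C(=O)O[C@H]2CC3=C[C@H](C/C(C)=C/[C@@H](OC(=O)C4CCC(F)(F)CC4)[C@H]12)OC3=O`) gives 6400 nM and compound 3 (`C=C1C(=O)O[C@H]2CC3=C[C@H](C/C(C)=C/[C@@H](OC(=O)C45CCC(C)(C(=O)O4)C5(C)C)[C@H]12)OC3=O`) gives 3400 nM. Compound 3 therefore lies within the usual scatter of both other compounds, as shown by a 1.5-fold higher number from compound 1 to compound 3 (0.17 log units; within the scatter) and a 1.9-fold lower number from compound 2 to compound 3 (0.27 log units; within the scatter). Only a 2.8-fold higher number from compound 1 to compound 2 (0.44 log units; beyond the scatter) goes beyond the scatter, and it is modest.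

Compound 4 (`C=C1C(=O)O[C@H]2CC3=C[C@H](C/C(C)=C/[C@@H](OC(=O)/C=C/c4cccs4)[C@H]12)OC3=O`) has not yet been measured. Its change from compound 3 is a group of 7 heavy atoms (6 carbon, 1 sulfur; one five-membered aromatic ring with 1 hetero atom) in place of a group of 11 heavy atoms (9 carbon, 2 oxygen; one five-membered non-aromatic ring of carbon only, one five-membered non-aromatic ring with 1 hetero atom), on a carbonyl carbon, and the entering group is 2-(thiophen-2-yl)ethenyl. Among the compounds with values here, no measured compound carries this group, so the three steps above serve only as a guide to how far exchanges at this place have moved the number. Within the data shown here, compound 1, the only measured compound with an aromatic ring in this group, gives 2300 nM, which supports a slight lean toward lower numbers. The expected step, which should stay within the scatter, is a 1.1-fold lower number from compound 3 to compound 4 (0.05 log units; within the scatter). For compound 4, the estimated value is 3000 nM, with an expected range from 1300 nM to 7000 nM.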

Compound 4, half-maximal inhibitory concentration: 4300 nM
Beside the measured number, compound 4's estimate is 1.4-fold (0.16 log units) below it; the range from low to high includes it.
By their numbers in this assay, from the lowest: compounds 1, 3, 4 and 2 (each within the scatter of the next, the first and the last beyond it).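

In this assay, the 2-(thiophen-2-yl)ethenyl group, the first here to bring a five-membered aromatic ring with sulfur to this carbonyl carbon, stays within the scatter of all three earlier groups (a 1.3-fold higher number from compound 3 to compound 4 (0.10 log units; within the scatter); a 1.5-fold lower number from compound 2 to compound 4 (0.17 log units; within the scatter); a 1.9-fold higher number from compound 1 to compound 4 (0.27 log units; within the scatter)). Across these four compounds, then, a fourth quite different group at this place adds no new separation, and the 4-acetylphenyl and 4,4-difluorocyclohexyl pair of compound 1 and compound 2 remains the only one beyond the scatter. Nothing available explains the small differences that remain.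

The compounds shown leave open whether a group carrying an amine or a carboxylic acid, or a long straight carbon chain, would stay in this same narrow span. They also leave open whether any exchange at this place can move the number well beyond the values seen so far.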